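Dropping a Methyl Toward the Phenylsulfonamide of Compound 1

The compounds below may be only part of what the source reports. "The series", "measured", "known", "first", "only" and "open" are said of these compounds alone.

Two compounds set the frame. Compound 1 `COc1ccccc1C(=O)NCc1ccc(CNS(=O)(=O)c2ccccc2)cc1` carries a phenylsulfonamide on one end and a methoxy-substituted benzamide on the other; in an assay on MDA-MB-231 cells for binding affinity to C-X-C chemokine receptor type 4 (Homo sapiens), read by immunofluorescence and microscopy, with stated times of 10 min and 30 min (on this read-out higher numbers stand for an effect only at larger amounts of compound and lower numbers for an effect already at smaller amounts), compound 1 gives 1 nM. Compound 2 `Cc1ccc(S(=O)(=O)NCc2ccc(CNC(=O)c3cccc(C)c3)cc2)cc1` instead pairs a 4-methylphenyl sulfonamide with a methyl-substituted benzamide, and in this assay compound 2 gives 1000 nM, the highest of the two numbers and a gap from compound 1 that lies far beyond the scatter. Since the two compounds differ in two places, the data alone cannot say which change carries that gap.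

Compound 3 `Cc1cccc(C(=O)NCc2ccc(CNS(=O)(=O)c3ccccc3)cc2)c1` tests one of them: it keeps the benzamide of compound 2 and changes only the sulfonamide aryl, (hydrogen in place of methyl on an aromatic carbon), so that its sulfonamide half now matches compound 1. Because compound 1 with the same phenylsulfonamide gives 1 nM, a move toward lower numbers is expected, but a step the full size of the gap is not, since the benzamide still differs; the expected step is a 6.7-fold lower number from compound 2 to compound 3 (0.82 log units; beyond the scatter). Compound 3 is therefore estimated at 150 nM, within 15 nM to 1200 nM.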

Compound 3, effective concentration (reported as EC, without a stated level of effect): 1000 nM
Beside the measured number, compound 3's estimate is 6.7-fold (0.82 log units) below it; the measured number falls inside the stated range.
By their numbers in this assay, from the lowest: compound 1; then compounds 2 and 3 (each within the scatter of the next).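

In this assay, the change from 4-methylphenyl to phenyl on the sulfonamide gives no change at the digits printed from compound 2 to compound 3 (within the scatter), so with the 3-methylphenyl benzamide in place, hydrogen and methyl at this aromatic carbon cannot be told apart. With the phenylsulfonamide held constant, 3-methylphenyl in place of 2-methoxyphenyl on a carbonyl carbon gives a 1000-fold higher number from compound 1 to compound 3 (3.00 log units; beyond the scatter), which places the large gap that the first two compounds left unassigned on the benzamide side of these matched compounds. The data offer no measurement that would explain either the flat step at the sulfonamide or the large step at the benzamide.

The compounds leave open whether the large step follows the methoxy group itself, the loss of the methyl, or where the substituent sits on the benzamide ring, since that single change replaces one substituted aryl with another. They also leave open whether the sulfonamide aryl would stay as flat with the 2-methoxyphenyl benzamide of compound 1, and whether an amine or a carboxylic acid in place of the methyl would move the number at all.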